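The source may report more compounds than this note shows. Statements on the series, on what has been measured and on what is new or still open speak of the compounds shown alone.

In a physicochemical assay for solubility, read by nephelometry, in phosphate buffer, measured as kinetic solubility, at pH 6.5 (on this read-out lower numbers stand for lower solubility and higher numbers for higher solubility), compound 1 (`CCOC(=O)C1=C(C)N/C(=C/c2cc(C)n(-c3ccc(CN(C)C)cc3)c2C)C1=O`) gives 12.5 ug/mL as the highest of the three numbers at hand. Compound 2 (`CCOC(=O)C1=C(C)N/C(=C/c2cc(C)n(-c3cccc(C(F)(F)F)c3)c2C)C1=O`) reads 2.1 ug/mL and compound 3 (`CCOC(=O)C1=C(C)N/C(=C/c2cc(C)n(-c3cc(OC)c(OC)c(OO)c3)c2C)C1=O`) reads 3.1 ug/mL on the same scale. The account now follows the change to compound 4 (`CCOC(=O)C1=C(C)N/C(=C/c2cc(C)n(-c3ccc(SC(F)(F)F)cc3)c2C)C1=O`) in which (trifluoromethyl)sulfanyl stands in place of (dimethylamino)methyl on an aromatic carbon ((trifluoromethyl)sulfanyl in place of (dimethylamino)methyl on an aromatic carbon) of the six-membered aromatic ring. For the measured compounds named here, one measured step bears on this directly, a 6.0-fold lower number from compound 1 to compound 2 (0.77 log units; beyond the scatter) when 3-(trifluoromethyl)phenyl comes in place of 4-((dimethylamino)methyl)phenyl on an aromatic nitrogen. Compound 3 also lacks the (dimethylamino)methyl group and likewise shows a lower number than compound 1. Compound 4 loses that group too, so a step of similar, modest size towards a lower number and beyond the scatter is expected in this assay for it. The expected change is a 6.3-fold lower number from compound 1 to compound 4 (0.80 log units; beyond the scatter) according to this estimate. Compound 4 is estimated at 2 ug/mL with an expected range from 0.8 ug/mL to 5 ug/mL for its measurement.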

Compound 4, solubility: 1 ug/mL
Beside the measured number, compound 4's estimate is 2.0-fold (0.30 log units) above it; low and high end bracket the measured number.
By their numbers in this assay, from the lowest: compound 4; then compounds 2 and 3 (each within the scatter of the next); then compound 1.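

In this assay, the exchange at this position alone, on an aromatic carbon para to a large group, gives a 13-fold lower number from compound 1 to compound 4 (1.10 log units; beyond the scatter). The earlier step to compound 2 replaced the whole 4-((dimethylamino)methyl)phenyl, whereas here the six-membered aromatic ring stays and only its substituent changes, so this position on its own can carry a step that reads as large rather than modest. Nothing shown offers a measured explanation for this step.

The compounds shown leave open whether the step follows from the departure of (dimethylamino)methyl or from the arrival of (trifluoromethyl)sulfanyl. A hydrogen, a morpholine or a carboxylic acid at this same carbon, or a longer chain ending in the dimethylamino group, would help to separate the two readings.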